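The source may hold more compounds than are shown below. What is called first, only, known or untested is meant among the compounds shown, and "the series" means these compounds.

Three compounds share a core here: compound 1 `Brc1ccc(-c2nnc(Nc3ccccc3)s2)cc1`, compound 2 `CC(C)(C)c1ccc(-c2nnc(Nc3ccc(Br)cc3)s2)cc1` and compound 3 `Cc1ccc(Nc2nnc(-c3ccc(Br)cc3)s2)cc1`. In an assay on isolated protein for inhibition of beta-glucuronidase (Bos taurus), read by spectrophotometry, with a stated time of 30 min (on this read-out higher numbers stand for weaker inhibition and lower numbers for stronger inhibition), compound 1 gives 40200 nM, the highest of the three numbers, yet compound 2 at 32200 nM and compound 3 at 28600 nM both lie within the scatter of it, so nothing separates the three. Compound 4 `COc1cccc(Nc2nnc(-c3ccc(Br)cc3)s2)c1` is not yet measured. It differs from compound 1 by methoxy in place of hydrogen on an aromatic carbon. Within the data shown here, the one measured step that bears on this kind of change is a 1.4-fold lower number from compound 1 to compound 3 (0.15 log units; within the scatter), a methyl in place of hydrogen on an aromatic carbon of the same ring, and it stayed within the scatter; no measured step covers a methoxy. On that basis one expects no step beyond the scatter for compound 4, and the step from compound 1 to compound 4 is estimated at a 1.1-fold lower number from compound 1 to compound 4 (0.06 log units; within the scatter). Compound 4 is therefore expected to give about 35000 nM in this assay, with a range from 15000 nM to 80000 nM.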

Compound 4, half-maximal inhibitory concentration: 31100 nM
The estimate for compound 4 lay 1.1-fold (0.05 log units) above the measured number, and the stated range covers the measured number.
By their numbers in this assay, from the lowest: compounds 3, 4, 2 and 1 (each within the scatter of the next).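

In this assay, methoxy in place of hydrogen on an aromatic carbon, meta to a large group, gives a 1.3-fold lower number from compound 1 to compound 4 (0.11 log units; within the scatter) and so leaves the number where it was. The earlier compounds shown here showed this only for methyl, through a 1.4-fold lower number from compound 1 to compound 3 (0.15 log units; within the scatter) on the same kind of ring. The new step extends it to a group of 2 heavy atoms carrying 1 hydrogen-bond acceptor, which still brings no change that can be told from the scatter.

The compounds shown leave open whether any group on this ring can move the number beyond the scatter at all, since no step among them does so. As far as these compounds go, it also remains open whether an amine or a carboxylic acid at this place, or a longer chain on the oxygen, would behave as methoxy does. Nothing available speaks to why this step is so small.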